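The compounds below may be only part of what the source reports. "The series", "measured", "known", "first", "only" and "open" are said of these compounds alone.

In an ADME assay on Huh-7 cells (Homo sapiens) for cytotoxicity (a higher number here means a weaker inhibitor, a lower number a stronger inhibitor), compound 3 `COc1ccc(-c2csc(Nc3cc4[nH]c(=O)cnc4cc3N(C)C3CCCCC3)n2)cc1` gives 15000 nM, the lowest of the three numbers seen so far in this series. Compound 2 `CN(c1cc2ncc(=O)[nH]c2cc1Nc1nc(-c2ccccc2)cs1)C1CCCCC1` gives 62500 nM, and compound 1 `CN(c1cc2ncc(=O)[nH]c2cc1NC(=S)Nc1ccc(F)cc1)C1CCCCC1` gives 64300 nM. Going by the values given here, the one measured step that bears on the next change is a 4.2-fold lower number from compound 2 to compound 3 (0.62 log units; beyond the scatter), a modest move. The step now under consideration leads to compound 4 `CN(c1cc2ncc(=O)[nH]c2cc1Nc1nc(C(F)(F)F)cs1)C1CCCCC1`, and it is trifluoromethyl in place of 4-methoxyphenyl on an aromatic carbon. Since the methoxy that carried the lowering in that earlier step leaves along with the aromatic ring, a move back toward the numbers of compound 2 is expected rather than a further fall. Compound 4 is therefore estimated at 50000 nM, with a range of 15000 nM to 150000 nM, which is expected to mean a 3.3-fold higher number from compound 3 to compound 4 (0.52 log units; beyond the scatter).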

Compound 4, half-maximal inhibitory concentration: 37400 nM
For compound 4 the middle estimate is 1.3-fold (0.13 log units) above the measured one; the measured number falls inside the stated range.
By their numbers in this assay, from the lowest: compound 3; then compounds 4, 2 and 1 (each within the scatter of the next).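

In this assay, trifluoromethyl on this aromatic carbon, next to the ring nitrogen, does not hold the level of 4-methoxyphenyl: a 2.5-fold higher number from compound 3 to compound 4 (0.40 log units; beyond the scatter). Against phenyl it gives a 1.7-fold lower number from compound 2 to compound 4 (0.22 log units; within the scatter), and exchanging the whole group on the nitrogen gives a 1.7-fold lower number from compound 1 to compound 4 (0.24 log units; within the scatter), so among these compounds only compound 3 stands apart. No measurement here accounts for these differences.

Still open, on these data alone, is whether the lowering needs the methoxy itself or would also appear with 4-hydroxyphenyl or 4-chlorophenyl. A plain methyl in place of trifluoromethyl would test whether this position responds to small groups at all.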